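From 4-fluorophenyl to 4-hydroxyphenyl on a shared core

The compounds below may be only part of what the source reports. "The series", "measured", "known", "first", "only" and "open" are said of these compounds alone.

Going by the values given here, in a functional assay, read by Griess assay, with a stated time of 2.5 h (a higher number here means a weaker inhibitor, a lower number a stronger inhibitor), compound 1 `COc1cc(OC)c(OC)cc1/C=C/C(=O)c1ccccc1` gives 2.01 ug/mL and compound 2 `COc1cc(OC)c(OC)cc1/C=C/C(=O)c1ccc(F)cc1` gives 1.96 ug/mL, so compound 2 cannot be told apart from the only other measured compound. Among the compounds with values here, the one measured step is a 1.0-fold lower number from compound 1 to compound 2 (0.01 log units; within the scatter). Compound 3 `COc1cc(OC)c(OC)cc1/C=C/C(=O)c1ccc(O)cc1` has hydroxy in place of fluoro on an aromatic carbon. That measured step bears on this place but brought in fluoro, not hydroxy, so it offers only weak guidance. In this assay the expected result is a 1.0-fold higher number from compound 2 to compound 3 (0.01 log units; within the scatter), with no change beyond the scatter. Compound 3 is estimated at 2 ug/mL, with an expected range of 0.9 ug/mL to 4.5 ug/mL.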

Compound 3, half-maximal inhibitory concentration: 2.5 ug/mL
Estimate against measurement, compound 3: 1.3-fold (0.10 log units) below; the range from low to high includes it.
By their numbers in this assay, from the lowest: compounds 2, 1 and 3 (each within the scatter of the next).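

Hydroxy in place of fluoro gives a 1.3-fold higher number from compound 2 to compound 3 (0.11 log units; within the scatter) and hydroxy in place of hydrogen gives a 1.2-fold higher number from compound 1 to compound 3 (0.09 log units; within the scatter) in this assay. Hydrogen, fluoro and hydroxy at this place, para to a large group, therefore cannot be told apart, even though hydroxy alone brings a hydrogen-bond donor. Nothing measured here accounts for this flat result.

From the compounds shown here alone, whether an amine, a carboxylic acid or a longer alkyl chain at this place would move the number beyond the scatter stays open. So does whether any group elsewhere on the shared core would do so.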